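The compounds below may be only part of what the source reports. "The series", "measured", "known", "first", "only" and "open" are said of these compounds alone.

Compound 1 `C=CC1=C(C(=O)NCc2ccc(C)cc2)C(c2ccc(F)cc2)OC1`: 62100 nM
Compound 2 `C=CC1=C(C(=O)NCc2ccc(Cl)cc2)C(c2ccc(F)cc2)OC1`: 36900 nM

In a functional assay on QGY7701 cells (Homo sapiens) for cytotoxicity, read by MTT assay, with a stated time of 24 h (on this read-out higher numbers stand for weaker inhibition and lower numbers for stronger inhibition), compound 2 gives 36900 nM, the lower of the two numbers, yet the step of a 1.7-fold lower number from compound 1 to compound 2 (0.23 log units; within the scatter) stays within the scatter, so compound 2 and compound 1 stand level. Compound 3 `C=CC1=C(C(=O)NCC(C)C)C(c2ccc(F)cc2)OC1` carries isopropyl in place of 4-chlorophenyl on a saturated chain carbon bound to an amide-type nitrogen. Going by the values given here, no measured step bears on this exchange; the only step available concerns a substituent on the ring that here disappears. Compound 3 is therefore expected near compound 2, with a slight drift toward weaker inhibition allowed, estimated as a 1.6-fold higher number from compound 2 to compound 3 (0.21 log units; within the scatter). The expected value for compound 3 is 60000 nM, with a range of 20000 nM to 160000 nM.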

Compound 3, half-maximal inhibitory concentration: > 100000 nM
Compound 3 gave a limit, no number; the forecaster's own chance of this, stated with the estimate: 20%; middle value at least 1.6-fold (0.22 log units) away from the limit.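

In this assay compound 3 gives > 100000 nM, which is a limit of the assay and not a number. Replacing 4-chlorophenyl with isopropyl on a saturated chain carbon bound to an amide-type nitrogen gives a step beyond the scatter, an at least 2.7-fold higher number from compound 2 to compound 3 (0.43 log units; beyond the scatter), while the floor of the other comparison, an at least 1.6-fold higher number from compound 1 to compound 3 (0.20 log units; that floor lies within the scatter), lies within it and settles nothing. The size of the change therefore remains bounded only on one side: the limit of > 100000 nM in this assay, at which 1 of the 3 values shown sits.

As far as these compounds go, how far compound 3 lies past its limit stays open. So does whether an unsubstituted benzyl group, a longer alkyl chain or an amine at this place would stay level with compound 1 and compound 2.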